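Working notes on the step to compound 3

The source may hold more compounds than are shown below. What is called first, only, known or untested is meant among the compounds shown, and "the series" means these compounds.

- compound 1 `CC(C)=CCC[C@]1(C)/C=C/[C@@H](OC(=O)C=C(C)C)[C@](C)(O)/C=C/C(=O)/C(CN(C)C)=C\C1` at 140 nM
- compound 2 `CC(C)=CCC[C@]1(C)/C=C/[C@@H](OC(=O)C=C(C)C)[C@](C)(O)/C=C/C(=O)/C(COC(=O)c2ccc([N+](=O)[O-])cc2)=C\C1` at 830 nM

In a functional assay on HL-60 cells (Homo sapiens) for antiproliferative activity, read by MTT assay, with a stated time of 48 h (a higher number here means a weaker inhibitor, a lower number a stronger inhibitor), compound 2 is the higher of the two at 830 nM so far. Compound 3 `CC(C)=CCC[C@]1(C)/C=C/[C@@H](OC(=O)C=C(C)C)[C@](C)(O)/C=C/C(=O)/C(Cn2cc(CO)nn2)=C\C1` carries this change: 4-(hydroxymethyl)-1H-1,2,3-triazol-1-yl in place of ((4-nitrophenyl)carbonyl)oxy on a saturated chain carbon bound to a double-bonded ring carbon relative to compound 2. Within the data shown here, the only measured step at this place is a 5.9-fold higher number from compound 1 to compound 2 (0.77 log units; beyond the scatter) and it is modest. No 4-(hydroxymethyl)-1H-1,2,3-triazol-1-yl compound has been measured, so only a modest step to a lower number is expected in this assay here. Compound 3 is estimated at 380 nM with an expected range from 110 nM to 1300 nM in this series. The expected change is a 2.2-fold lower number from compound 2 to compound 3 (0.34 log units; beyond the scatter) on this estimate.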

Compound 3, half-maximal inhibitory concentration: 3200 nM
The estimate for compound 3 lay 8.4-fold (0.93 log units) below the measured number; measured number outside the range, above it.
By their numbers in this assay, from the lowest: compound 1; then compound 2; then compound 3.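

In this assay the 4-(hydroxymethyl)-1H-1,2,3-triazol-1-yl group on a saturated chain carbon bound to a double-bonded ring carbon gives a 3.9-fold higher number from compound 2 to compound 3 (0.59 log units; beyond the scatter) and a 23-fold higher number from compound 1 to compound 3 (1.36 log units; beyond the scatter) and so ranks last of the three groups at this place. Size alone does not set the order here, since ((4-nitrophenyl)carbonyl)oxy, with more heavy atoms, gives the lower number of this pair.

Still open, going by these compounds, is whether the triazole ring or its hydroxymethyl carries the loss, and how a piperidine or a diethylamino group would compare with dimethylamino at this place. Nothing at hand bears on the cause of this order.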